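Oxanylcarbonyl Amide in Place of Isobutyl on the Ring Nitrogen

The compounds below may be only part of what the source reports. "The series", "measured", "known", "first", "only" and "open" are said of these compounds alone.

Compound 1 `CC(C)CN1CCc2nc(C#Cc3ccccc3)sc2C1` gives 650 nM in an assay on HEK293 cells for negative allosteric modulation of metabotropic glutamate receptor 5 (Homo sapiens), read by FLIPR, with a stated time of 1 h; a lower number here means a stronger inhibitor, a higher number a weaker inhibitor.
Compound 2 `CC(=O)N1CCc2nc(C#Cc3ccccc3)sc2C1` gives 90 nM.
Compound 3 `O=C(C1CC1)N1CCc2nc(C#Cc3ccccc3)sc2C1` gives 290 nM.

Compound 1 has the highest number of the three, that is, it is the weakest inhibitor measured. Compound 4 `O=C(C1CCOCC1)N1CCc2nc(C#Cc3ccccc3)sc2C1` differs from it in one place: (oxan-4-yl)carbonyl in place of isobutyl on an amine nitrogen in a ring. Two measured steps swap the same isobutyl for an amide: a 7.2-fold lower number from compound 1 to compound 2 (0.86 log units; beyond the scatter) and a 2.2-fold lower number from compound 1 to compound 3 (0.35 log units; beyond the scatter), both lowering the number. A third step, a 3.2-fold higher number from compound 2 to compound 3 (0.51 log units; beyond the scatter), shows that a larger group on the carbonyl carbon raises it again. The oxanyl group is larger still, so a small lowering, close to the scatter, is expected: a 1.6-fold lower number from compound 1 to compound 4 (0.21 log units; within the scatter). Compound 4 is estimated at 400 nM, within 130 nM to 1200 nM.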

Compound 4, half-maximal inhibitory concentration: > 10000 nM
Compound 4 gave a limit, no number; the forecaster's own chance of this, stated with the estimate: 3%; at least 25-fold (1.39 log units) between middle value and limit.
By their numbers in this assay, from the lowest: compound 2; then compound 3; then compound 1. At a limit, above all of these: compound 4.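

Compound 4 stands at a limit, not a number: the limit of > 10000 nM in this assay, at which 1 of the 4 values shown sits. Even so, the change is large from each of the other compounds: an at least 15-fold higher number from compound 1 to compound 4 (1.18 log units; beyond the scatter), an at least 34-fold higher number from compound 3 to compound 4 (1.53 log units; beyond the scatter) and an at least 110-fold higher number from compound 2 to compound 4 (2.04 log units; beyond the scatter). On this ring nitrogen, then, having an amide does not by itself lower the number, since the acetyl of compound 2 and the cyclopropylcarbonyl of compound 3 do so but the (oxan-4-yl)carbonyl of compound 4 does not.

On these data alone, whether this rise goes with the ring oxygen or with the six-membered ring itself stays open. Cyclohexylcarbonyl, the same ring with carbon in place of that oxygen, would tell the two apart.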